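The compounds below may be only part of what the source reports. "The series", "measured", "known", "first", "only" and "open" are said of these compounds alone.

The series rests on a shared core, seen in compound 1 `CON(C)C(=O)/C=C1\CCc2ccc(F)cc21`, where the group on the carbonyl carbon is varied. In a functional assay on the whole organism with Rattus norvegicus as the target, at a dose of 20 mg/kg by the oral route (on this read-out higher numbers stand for more inhibition at the one dose given (going by the name of the read-out) and lower numbers for less inhibition), compound 1 gives 14%. Compound 2 `O=C(/C=C1\CCc2ccc(F)cc21)N1CCC1` carries azetidin-1-yl in place of methoxy(methyl)amino on that carbonyl carbon, and in this assay compound 2 gives 0%, which is a number 14 percentage points lower from compound 1 to compound 2 (beyond the scatter). On the numbers shown, compound 2 stands lowest of the two measured compounds, with compound 1 as its only neighbour.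

Compound 3 `O=C(/C=C1\CCc2ccc(F)cc21)NC1CC1` has not been measured. It differs from compound 2 as follows: cyclopropylamino in place of azetidin-1-yl on a carbonyl carbon. Going by the values given here, no measured step exchanges a ring amine for a secondary amide on the carbonyl carbon, so neither the step from compound 1 to compound 2 nor any other number bears directly on this change. Among the compounds with values here, the only guidance is that both measured values lie in the lower part of the scale, and the change is counted as a rearrangement of the same atoms.

For compound 3 a step of a number 8 percentage points higher from compound 2 to compound 3 (within the scatter) is expected in this assay, small and upward. The value for compound 3 is estimated at 8%, with a range from 0% to 25%.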

Compound 3, a percentage reported as inhibition, in the whole organism at one dose (the size of the read-out at that dose, not a potency): 7%
Compound 3: the middle estimate sits 1 percentage points above what was measured; measured number inside the range.
By their numbers in this assay, from the lowest: compounds 2, 3 and 1 (each within the scatter of the next, the first and the last beyond it).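

In this assay, cyclopropylamino with its 1 hydrogen-bond donor on the carbonyl carbon, in place of azetidin-1-yl with 0 hydrogen-bond donors, gives a number 7 percentage points higher from compound 2 to compound 3 (within the scatter), so this exchange of a ring amine for a secondary amide of the same atoms has no effect that can be read on this measure. Against the methoxy(methyl)amino group of compound 1, the same group gives a number 7 percentage points lower from compound 1 to compound 3 (within the scatter), so compound 3 cannot be told apart from either of the others, even though compound 1 and compound 2 are separated beyond the scatter; the three groups therefore do not yet fall into a clear order at this position, and only the gap between compound 1 and compound 2 can be read. Nothing measured here offers an explanation for these numbers.

Going by these compounds, it remains open whether a larger ring amine such as piperidin-1-yl, or an open-chain amine such as dimethylamino, on this carbonyl carbon would rise clearly above these low values. On these data alone, it is equally open whether a carboxylic acid in place of the amide would do so, or whether any change here would matter more than a change elsewhere on the shared core.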